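The source may hold more compounds than are shown below. What is called first, only, known or untested is meant among the compounds shown, and "the series" means these compounds.

Compound 1, `Cc1cc(C)cc(-n2nncc2CN2C(=O)C3(C(C#N)=C(N)Oc4c(N)cc5nc6ccccc6nc5c43)c3ccccc32)c1`, in a functional assay on MCF7 cells (Homo sapiens) for antiproliferative activity, read by MTT assay, with a stated time of 48 h (a higher number here means a weaker inhibitor, a lower number a stronger inhibitor), reaches only the limit of the assay, > 50000 nM.
Compound 2, `CCc1cccc(CC)c1-n1nncc1CN1C(=O)C2(C(C#N)=C(N)Oc3c(N)cc4nc5ccccc5nc4c32)c2ccccc21`, likewise stops at the limit, > 50000 nM.
Compound 3, `N#CC1=C(N)Oc2c(N)cc3nc4ccccc4nc3c2C12C(=O)N(Cc1cnnn1-c1cc(Cl)ccc1Cl)c1ccccc12`, gives 33200 nM in this assay.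

Among the measured compounds shown here, compound 3 thus holds the only number in the set; the two other values are limits (the limit of > 50000 nM in this assay, at which 2 of the 3 values shown sit). Compound 4, `Cc1ccc(Cl)cc1-n1nncc1CN1C(=O)C2(C(C#N)=C(N)Oc3c(N)cc4nc5ccccc5nc4c32)c2ccccc21`, differs from compound 3 by methyl in place of chloro on an aromatic carbon. The measured steps that bear on this aryl group are an at least 1.5-fold lower number from compound 1 to compound 3 (0.17 log units; that floor lies within the scatter) and an at least 1.5-fold lower number from compound 2 to compound 3 (0.17 log units; that floor lies within the scatter), both floors only, while a step that the two limits leave unreadable from compound 1 to compound 2. Nothing shown tells whether a single methyl for chloro exchange moves the number beyond the scatter. The expectation is a small step toward the weaker side, a 1.4-fold higher number from compound 3 to compound 4 (0.13 log units; within the scatter). Compound 4 is therefore estimated at 45000 nM, between 20000 nM and 90000 nM.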

Compound 4, half-maximal inhibitory concentration: 43500 nM
Compound 4: middle estimate off by 1.0-fold (0.01 log units), on the high side, and the stated range covers the measured number.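

In this assay, methyl in place of chloro on this aromatic carbon, ortho to a large group and para to a chloro group, gives a 1.3-fold higher number from compound 3 to compound 4 (0.12 log units; within the scatter), so this exchange does not move the number beyond the scatter. Against the two aryl groups held at a limit, 5-chloro-2-methylphenyl yields floors only: an at least 1.1-fold lower number from compound 2 to compound 4 (0.06 log units; that floor lies within the scatter), and an at least 1.1-fold lower number from compound 1 to compound 4 (0.06 log units; that floor lies within the scatter). Those floors, like the unreadable step between compound 1 and compound 2, rest on a limit: the limit of > 50000 nM in this assay, at which 2 of the 4 values shown sit.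

Going by these compounds, whether an amine or a carboxylic acid on this aromatic carbon would move the number beyond the scatter stays open. Also open, on these data alone, is how far the 3,5-dimethylphenyl and 2,6-diethylphenyl groups lie from the chlorinated aryl groups.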